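The source may hold more compounds than are shown below. What is called first, only, known or untested is meant among the compounds shown, and "the series" means these compounds.

In an ADME assay on BaF3 cells (Mus musculus) for antiproliferative activity, read by CCK-8 assay, with a stated time of 72 h (on this read-out higher numbers stand for weaker inhibition of growth and lower numbers for stronger inhibition of growth), three compounds have been measured so far. Compound 1 `Cc1ccc(C(=O)Nc2ccc(CN3CCN(C)CC3)c(C(F)(F)F)c2)cc1C#Cc1ncc2cccnn12` gives 940 nM, compound 2 `O=C(CCSc1ccc2c(/C=C/c3ccccn3)n[nH]c2c1)Nc1cccc(F)c1` gives 6590 nM and compound 3 `O=C(CCSc1ccc2c(/C=C/c3ccccn3)n[nH]c2c1)Nc1cccc(Cl)c1` gives 9350 nM. Compound 3 therefore shares the weak end of this small range with compound 2, while compound 1 lies clearly lower.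

Compound 4 `CN1CCN(c2cccc(NC(=O)CCSc3ccc4c(/C=C/c5ccccn5)n[nH]c4c3)c2)CC1` differs from compound 3 in one place: 4-methylpiperazin-1-yl in place of chloro on an aromatic carbon. In plain terms, 4-methylpiperazin-1-yl stands in place of chloro on an aromatic carbon. Going by the values given here, the only measured single change is a 1.4-fold higher number from compound 2 to compound 3 (0.15 log units; within the scatter), and it exchanges one halogen for another, so it says little about a group this much larger. Compound 1 also carries a 4-methylpiperazin-1-yl group, but on a different core, so its 940 nM is only a loose hint. The expected change is a 3.1-fold lower number from compound 3 to compound 4 (0.49 log units; beyond the scatter), towards stronger inhibition of growth, though this expectation rests on thin evidence. For compound 4 the estimated value is 3000 nM, with an expected range of 700 nM to 10000 nM.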

Compound 4, concentration for 50% growth inhibition: > 10000 nM
Compound 4 ended at the assay's limit; the forecaster's own chance of this, stated with the estimate: 5%; middle value at least 3.3-fold (0.52 log units) away from the limit.
By their numbers in this assay, from the lowest: compound 1; then compounds 2 and 3 (each within the scatter of the next). At a limit, above all of these: compound 4.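

In this assay compound 4 gives > 10000 nM, which is a limit of the assay and not a number. Until now this aromatic carbon had shown only one halogen exchanged for another, and the new result adds that a far larger group with a non-aromatic ring, 4-methylpiperazin-1-yl, brings no drop in the number, with only floors to read: an at least 1.0-fold higher number from compound 3 to compound 4 (0.02 log units; that floor lies within the scatter) and an at least 1.5-fold higher number from compound 2 to compound 4 (0.18 log units; that floor lies within the scatter). The true size of these steps stays unknown because the reading stops at the limit: the limit of > 10000 nM in this assay, at which 1 of the 4 values shown sits.

The compounds shown leave open whether a small group on this carbon, such as a primary amine or a hydroxyl group, would lower the number. They also leave open whether a carboxylic acid there would do so.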